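Changing the Aryl Group on the Sulfonyl Sulfur

The source may report more compounds than this note shows. Statements on the series, on what has been measured and on what is new or still open speak of the compounds shown alone.

Of the compounds shown here, three have been measured in a functional assay on the whole organism (strain Kunming) for inhibition, with Mus musculus as the target, with a stated time of 1 h, at a dose of 40 mg/kg by the oral route; a lower number here means less inhibition, a higher number more inhibition at the dose given (going by the name of the read-out). Compound 1 `O=C(/C=C/c1ccccc1)c1ccc(N2CCN(c3cccc(Cl)c3)CC2)cc1` gives 14.1%, compound 2 `COc1ccc(/C=C/C(=O)c2ccc(N3CCN(c4ccc(C)cc4C)CC3)cc2)cc1OC` gives 48.5%, and compound 3 `O=C(/C=C/c1ccccc1)c1ccc(N2CCN(S(=O)(=O)c3ccc4ccccc4c3)CC2)cc1` gives 35%. Among these three numbers compound 3 stands second highest: the nearest is compound 2, whose number lies beyond the scatter above it, and the furthest is compound 1, whose number lies beyond the scatter below it. No two of the measured compounds differ in only one place, so no single step can be read from them.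

Compound 4 `Cc1cc(C)c(S(=O)(=O)N2CCN(c3ccc(C(=O)/C=C/c4ccccc4)cc3)CC2)c(C)c1` has not yet been measured. It differs from compound 3 in one place: 2,4,6-trimethylphenyl in place of naphthalen-2-yl on a sulfonyl sulfur. Among the compounds with values here, nothing among the measured compounds shows what such a change does in this assay, and the shared core is kept. Compound 4 is therefore expected to land close to compound 3, with a step of a number 2 percentage points lower from compound 3 to compound 4 (within the scatter) that is not expected to go beyond the scatter in either direction. The estimate for compound 4 in this assay is 33%, with a range from 15% to 52%.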

Compound 4, a percentage reported as inhibition, in the whole organism at one dose (the size of the read-out at that dose, not a potency): 55.5%
Estimate against measurement, compound 4: 22.5 percentage points below; the measured number lies above the stated range.
By their numbers in this assay, from the lowest: compound 1; then compound 3; then compounds 2 and 4 (each within the scatter of the next).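

In this assay, placing 2,4,6-trimethylphenyl in place of naphthalen-2-yl on a sulfonyl sulfur gives a number 20.5 percentage points higher from compound 3 to compound 4 (beyond the scatter) with the shared core kept. Within the data shown here, this is the first single change, and it shows that the aryl group on this sulfur can by itself move the inhibition at the given dose beyond the scatter. Nothing measured here accounts for the size or direction of this step.

The step replaces two aromatic rings with one and brings in the methyl groups at the same time, so the compounds shown do not separate these two parts of the change. Also open, from the compounds shown here alone, is how a plain phenyl group, or a simple alkyl chain such as butyl, would fare on the same sulfur.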